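The source may hold more compounds than are shown below. What is called first, only, known or untested is meant among the compounds shown, and "the series" means these compounds.

Measured compounds:
compound 1, `CCCCCCC(=O)OCC(=O)NCc1ccc(O)c(OC)c1`, gives 170 nM in an assay on SH-SY5Y cells for agonist activity at transient receptor potential cation channel subfamily V member 1 (Homo sapiens), read by fluorescence and calcium flux, with a stated time of 25 min; a higher number here means that more compound is needed for the effect, a lower number that less compound is needed.
compound 2, `CCCCCCCCCCCC(=O)OCC(=O)NCc1ccc(O)c(OC)c1`, gives 370 nM.

Within the data shown here, compound 2 holds the higher of the two numbers, with compound 1 the only neighbour. Among the measured compounds shown here, the one step seen, a 2.2-fold higher number from compound 1 to compound 2 (0.34 log units; beyond the scatter), lengthens the chain on the ester side. Compound 3, `CCCCCCCCCCCCCCC(=O)OCC(=O)NCc1ccc(O)c(OC)c1`, carries the same change further: propyl in place of hydrogen on a saturated chain carbon, ten or more bonds along the chain from a carbonyl carbon. For the measured compounds named here, that earlier step is the only guide, and it bears directly on this one. A similar modest rise is therefore expected, a 1.8-fold higher number from compound 2 to compound 3 (0.24 log units; within the scatter), so compound 3 is estimated at 650 nM, within a range of 300 nM to 1400 nM.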

Compound 3, half-maximal effective concentration: 330 nM
For compound 3 the middle estimate is 2.0-fold (0.29 log units) above the measured one; the measured number falls inside the stated range.
By their numbers in this assay, from the lowest: compounds 1, 3 and 2 (each within the scatter of the next, the first and the last beyond it).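

Adding propyl this far along the chain leaves the reading in this assay flat (a 1.1-fold lower number from compound 2 to compound 3 (0.05 log units; within the scatter)), so the rise seen with the first lengthening does not continue. Even the full octyl addition (a 1.9-fold higher number from compound 1 to compound 3 (0.29 log units; within the scatter)) stays within the scatter, although compound 1 and compound 2 lie beyond it. No measured property is available here to account for this flat stretch.
From the compounds shown here alone, whether a still longer chain would change the number remains open. So does the effect of an amine or a carboxylic acid in place of the propyl.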